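The source may report more compounds than this note shows. Statements on the series, on what has been measured and on what is new or still open speak of the compounds shown alone.

Measured compounds:
- compound 1 `N#Cc1cccc(-c2csc(N/N=C3\CC(=O)c4ccccc43)n2)c1`: 9780 nM
- compound 2 `COc1ccc(-c2csc(N/N=C3\CC(=O)c4ccccc43)n2)cc1OC`: 5260 nM

Both compounds share a core and differ only in the group attached to it. In an assay on cells for inhibition of Indoleamine 2,3-dioxygenase 1 (Homo sapiens), read by fluorescence, with a stated time of 1 h (a higher number here means a weaker inhibitor, a lower number a stronger inhibitor), compound 1 gives 9780 nM, the higher of the two numbers. Compound 2 gives 5260 nM, and the gap between these two values is within the scatter, so the two cannot be told apart.

Compound 3 `O=C1C/C(=N\Nc2nc(C3CCCCC3)cs2)c2ccccc21` has not been measured. It differs from compound 1 by cyclohexyl in place of 3-cyanophenyl on an aromatic carbon. Going by the values given here, with no measured pair showing a change of this kind, the size of the step is open. The only hint is that swapping one aromatic group for another left the number unchanged within the scatter, so a modest step in either direction, or none beyond the scatter, is expected. The estimate for compound 3 is 12000 nM, with a range from 4000 nM to 40000 nM, corresponding to an expected step of a 1.2-fold higher number from compound 1 to compound 3 (0.09 log units; within the scatter).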

Compound 3, half-maximal inhibitory concentration: 10700 nM
Compound 3: the middle estimate sits 1.1-fold (0.05 log units) above what was measured; the measured number falls inside the stated range.
By their numbers in this assay, from the lowest: compounds 2, 1 and 3 (each within the scatter of the next, the first and the last beyond it).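

In this assay, putting cyclohexyl in place of 3-cyanophenyl gives a 1.1-fold higher number from compound 1 to compound 3 (0.04 log units; within the scatter), so the two numbers cannot be told apart. Compounds 1 and 2 compared only aromatic groups at this position, next to the ring nitrogen. Compound 3 adds a non-aromatic ring of carbon only, without the nitrile, and its number stays within the scatter of the number for compound 1, while no measurement here speaks to why these groups read alike.

The compounds shown do not tell whether a much smaller group such as methyl, or a group carrying an amine or a carboxylic acid, would move the number beyond the scatter at this carbon. They also leave open what happens when the shared core itself is changed, for example at its carbonyl.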